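This account rests on a few compounds, and the source may have more. Where it says the series, first, only, none or still open, it means among the compounds named here.

Measured so far:

- Compound 1 `CCN(CCC#N)c1nc(C)nc2c(-c3c(C)cc(OC)cc3OC)c(C)nn12`: 2.48 nM
- Compound 2 `COc1ccc(-c2c(C)nn3c(N4CCCC4)nc(C)nc23)c(C)c1`: 80.7 nM
- Compound 3 `CCC(CC)Nc1nc(C)nc2c(-c3ccc(OC)cc3)c(C)nn12`: 3.8 nM

In an assay on cell membranes for displacement of a labelled ligand from corticotropin-releasing factor receptor 1 (Rattus norvegicus) (on this read-out lower numbers stand for stronger inhibition and higher numbers for weaker inhibition), compound 1 gives 2.48 nM, the lowest of the three numbers. Compound 3 sits nearest, with a number that lies within the scatter of compound 1, so the two cannot be told apart on this read-out. Compound 2, which carries a cyclic amine on the shared core, is the furthest away, and the gap from compound 1 to compound 2 lies well beyond the scatter.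

Compound 4 `CCCCN(CC)c1nc(C)nc2c(-c3c(C)cc(OC)cc3OC)c(C)nn12` is not yet measured in this assay. It differs from compound 1 in one place: ethyl in place of cyano on a saturated chain carbon, two bonds along the chain from a nitrogen on an aromatic ring. Among the measured compounds shown here, no directly comparable step is available among the measured compounds. Compound 3, which carries only alkyl on the amine nitrogen, gives 3.8 nM, a number close to compound 1, which suggests that a nitrile in this chain is not required for a low number. The step from compound 1 to compound 4 is therefore expected to be small, a 1.6-fold higher number from compound 1 to compound 4 (0.21 log units; within the scatter), and not clearly beyond the scatter in either direction. For compound 4 the estimate is 4 nM, with a range from 1.5 nM to 12 nM.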

Compound 4, half-maximal inhibitory concentration: 1.72 nM
For compound 4 the middle estimate is 2.3-fold (0.37 log units) above the measured one; low and high end bracket the measured number.
By their numbers in this assay, from the lowest: compounds 4, 1 and 3 (each within the scatter of the next, the first and the last beyond it); then compound 2.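

Ethyl in place of cyano on a saturated chain carbon, two bonds along the chain from a nitrogen on an aromatic ring, gives a 1.4-fold lower number from compound 1 to compound 4 (0.16 log units; within the scatter) in this assay. Among the compounds shown here, this is the first direct pair at this position: with the rest of the structure unchanged, 2-cyanoethyl and butyl on the amine nitrogen cannot be told apart on this read-out, so the nitrile is not needed for a low number in this pair. No measurement on hand bears on why the exchange is tolerated.

Still open, on these data alone, is how a hydroxyl, an amine or a carboxylic acid at this place would read, and how a chain longer than butyl would. Also open, as far as these compounds go, is whether the same exchange would read alike with the aryl groups of compound 2 and compound 3.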